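The source may hold more compounds than are shown below. What is called first, only, known or untested is meant among the compounds shown, and "the series" means these compounds.

Compound 1 `N#Cc1c(N)nc(NCCCC2CCN(Cc3ccccc3)CC2)c(C#N)c1-c1ccccc1` gives 31.6 10^-6 cm/s in an ADME assay for permeability, using PAMPA, in phosphate buffer, with a stated time of 4 h, tested at 1 mg/mL; on this read-out lower numbers stand for lower permeability and higher numbers for higher permeability.
Compound 2 `N#Cc1c(N)nc(NCCC2CCN(Cc3ccccc3)CC2)c(C#N)c1-c1ccccc1` gives 34 10^-6 cm/s in this assay.
Compound 3 `N#Cc1cc(C#N)c(NCCCC2CCN(Cc3ccccc3)CC2)nc1N` gives 20.8 10^-6 cm/s in this assay.

The three measured compounds share a pattern of two nitriles and an amino group on a ring bearing one nitrogen, with a chain leading to a benzyl-substituted piperidine. Compound 1 and compound 2 differ in the length of that chain; the difference between the two cores is not broken down here, and their two values in this assay lie within the scatter of each other, so no order between them can be claimed. Compound 3 arises from compound 1 by hydrogen in place of phenyl on an aromatic carbon, a step of a 1.5-fold lower number from compound 1 to compound 3 (0.18 log units; within the scatter), a change that stays within the scatter of the measurement.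

Compound 4 `N#Cc1cc(C#N)c(NCCC2CCN(Cc3ccccc3)CC2)nc1N` has not yet been measured in this assay. It arises from compound 2 by the same change, (hydrogen in place of phenyl on an aromatic carbon). Within the data shown here, only one example of this change has been measured, that from compound 1 to compound 3, and it gave a small step; there is no second example to show whether the size is steady. Because the step from compound 1 to compound 3 was a 1.5-fold lower number from compound 1 to compound 3 (0.18 log units; within the scatter), the expected step from compound 2 to compound 4 is a 1.5-fold lower number from compound 2 to compound 4 (0.17 log units; within the scatter), of the same modest size. On this basis compound 4 is estimated to give about 23 10^-6 cm/s in this assay, with a likely range from 14 10^-6 cm/s to 36 10^-6 cm/s.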

Compound 4, apparent permeability: 14.4 10^-6 cm/s
For compound 4 the middle estimate is 1.6-fold (0.20 log units) above the measured one, within the range that was stated.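

Hydrogen in place of phenyl on the aromatic carbon opposite the ring nitrogen gives in this assay a step of a 2.4-fold lower number from compound 2 to compound 4 (0.37 log units; beyond the scatter). Set beside the earlier example, this step runs the same way, and the two do not differ by more than the scatter of two such steps allows: the same change on two cores in this assay, a 1.5-fold lower number (0.18 log units; within the scatter) from compound 1 to compound 3 and a 2.4-fold lower number (0.37 log units; beyond the scatter) from compound 2 to compound 4, 1.6-fold (0.19 log units) apart, within the scatter of two such steps Within these two pairs, then, the change carries from the core of compound 1 to the core of compound 2 with the same direction and a size that cannot be told apart, although only the second step on its own stands beyond the scatter, and two examples do not show that the size would hold on any further core.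

The compounds shown leave open how the read-out would respond if a methyl group, a methoxy group or a pyridyl ring stood on that aromatic carbon instead of phenyl or hydrogen. They also leave open whether the same step would appear with a longer chain than those in the four compounds, or with a group other than benzyl on the piperidine nitrogen, such as a cyclohexylmethyl group.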